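The source may report more compounds than this note shows. Statements on the series, on what has been measured and on what is new or still open speak of the compounds shown alone.

Measured in an ADME assay on Vero cells (Chlorocebus sabaeus) for cytotoxicity, read by MTT assay, with a stated time of 72 h; a higher number here means that more compound is tolerated, a lower number that less compound is tolerated:
compound 1 `CCOC(=O)c1c(-c2ccc(OC)cc2)oc2ccc(OCCCCCN3C(=O)C(=O)c4cc(F)ccc43)cc12`: 512 ug/mL
compound 2 `CCOC(=O)c1c(-c2ccc(OC)cc2)oc2ccc(OCCCCCCN3C(=O)/C(=N\OC)c4cc(F)ccc43)cc12`: 16 ug/mL

Compound 1 has the higher of the two numbers, and compound 2 lies far lower, a gap beyond the usual scatter. Compound 3 (`CCOC(=O)c1c(-c2ccc(OC)cc2)oc2ccc(OCCCCCN3C(=O)/C(=N\O)c4ccccc43)cc12`) differs from compound 1 at the end of the chain: a group of 12 heavy atoms (8 carbon, 2 nitrogen, 2 oxygen; one five-membered non-aromatic ring with 1 hetero atom, one six-membered aromatic ring of carbon only) in place of a group of 12 heavy atoms (8 carbon, 1 nitrogen, 2 oxygen, 1 fluorine; one five-membered non-aromatic ring with 1 hetero atom, one six-membered aromatic ring of carbon only), on a saturated chain carbon, five bonds along the chain from an oxygen on an aromatic ring. Going by the values given here, no measured pair shows this change alone. At that end compound 3 looks more like compound 2, although the two differ elsewhere too, so with 16 ug/mL for compound 2 a clear fall in this assay is expected, beyond the scatter. The expected step is a 4.0-fold lower number from compound 1 to compound 3 (0.60 log units; beyond the scatter). The estimate for compound 3 is 128 ug/mL, with an expected range of 32 ug/mL to 512 ug/mL.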

Compound 3, half-maximal cytotoxic concentration: 64 ug/mL
The estimate for compound 3 lay 2.0-fold (0.30 log units) above the measured number; the range from low to high includes it.
By their numbers in this assay, from the lowest: compound 2; then compound 3; then compound 1.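

In this assay, the swap of end group on a saturated chain carbon gives an 8.0-fold lower number from compound 1 to compound 3 (0.90 log units; beyond the scatter), so this place alone can move the number beyond the scatter. The swap changes several things at once: the entering group has 1 hydrogen-bond donor and 3 hydrogen-bond acceptors and no fluorine, while the leaving group has 0 donors, 2 acceptors and 1 fluorine. Nothing measured here ties the fall to any one of these differences. From the compounds shown here alone, whether losing the fluorine alone would matter remains open. So does how an amine or a carboxylic acid would fare at this place.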